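The source may hold more compounds than are shown below. What is called first, only, known or untested is meant among the compounds shown, and "the series" means these compounds.

Compound 2 `CC(c1ccc2ncc(-c3cnn(C)c3)cc2c1)n1nnc2ncc(-c3ccc(C(N)=O)c(F)c3)nc21` is the compound from which this account sets out. In an ADME assay on microsomes from liver (Homo sapiens) for metabolic stability, read by LC-MS, using NADPH, with stated times of 5 min and 30 min, tested at 1 uM (a higher number here means faster removal of the compound, a lower number slower removal), compound 2 gives 3 uL/min, the lowest of the three numbers that have been measured. Compound 1 `CC(c1ccc2ncc(-c3ccc(F)cc3)cc2c1)n1nnc2ncc(-c3ccncc3)nc21` gives 14 uL/min in this assay, and compound 3 `CC(c1ccc2ncc(-c3cnn(C)c3)cc2c1)n1nnc2ncc(-c3ccncc3)nc21` gives 22 uL/min, so compound 2 shows the slowest removal of the three, both gaps lying beyond the scatter.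

The change now followed leads to compound 4 `CC(c1cc2cc(-c3cnn(C)c3)cnc2cc1F)n1nnc2ncc(-c3ccc(C(N)=O)c(F)c3)nc21`. Relative to compound 2, it is fluoro in place of hydrogen on an aromatic carbon on the shared core, on a carbon that compound 2 carries as a plain aromatic hydrogen.

Two measured steps are known. The step of a 1.6-fold higher number from compound 1 to compound 3 (0.20 log units; within the scatter) exchanges one ring for another on the fused system and stays within the scatter. The step of a 7.3-fold higher number from compound 2 to compound 3 (0.87 log units; beyond the scatter) exchanges the group on the other ring system and is beyond the scatter. Within the data shown here, neither step adds fluoro to the fused ring, and neither alters the core in the way that compound 4 does, so no measured step bears directly on the change in hand.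

Compound 4 is therefore expected to give a number close to that of compound 2, with the step of a 1.3-fold higher number from compound 2 to compound 4 (0.12 log units; within the scatter) expected to lie within the scatter. Compound 4 is estimated at 4 uL/min in this assay, with a range from 2 uL/min to 9 uL/min.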

Compound 4, intrinsic clearance in a liver preparation (reported as CLH), per the amount of preparation that the assay uses: 2 uL/min
Compound 4: the middle estimate sits 2.0-fold (0.30 log units) above what was measured, and the stated range covers the measured number.
By their numbers in this assay, from the lowest: compounds 4 and 2 (each within the scatter of the next); then compounds 1 and 3 (each within the scatter of the next).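

In this assay, placing fluoro in place of hydrogen on an aromatic carbon of the shared core, ortho to a large group, gives a 1.5-fold lower number from compound 2 to compound 4 (0.18 log units; within the scatter), so the fluoro is taken up at this position with no difference from the hydrogen that can be told apart from the scatter. The earlier steps exchanged only the groups carried on the ring systems, which leaves this as the only step shown that reads this carbon directly, and here the read-out of compound 2 is held rather than shifted. Nothing available accounts for this result, and it can be stated only as an observation on this one pair.

The compounds shown leave open whether this carbon would behave the same way with chloro, methoxy or an amine in place of the fluoro, or whether other aromatic carbons of that ring would accept fluoro equally. They also leave open whether the fluoro gives the same outcome when pyridin-4-yl stands in place of 4-carbamoyl-3-fluorophenyl, as it does in compound 3 at 22 uL/min, where the number has more room to fall.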